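Acetyl removal from compound 2: expected solubility step

This account rests on a few compounds, and the source may have more. Where it says the series, first, only, none or still open, it means among the compounds named here.

Measured so far in a physicochemical assay for solubility, read by HPLC (a lower number here means a less soluble compound, a higher number a more soluble compound), for two compounds:
- compound 1 `COc1cccc2cc(CSc3nc4cncnc4n3[C@@H]3O[C@H](COC(C)=O)[C@@H](OC(C)=O)[C@H]3OC(C)=O)c(=O)oc12` gives 78.3 ug/mL
- compound 2 `COc1cccc2cc(CSc3nc4cncnc4n3[C@@H]3O[C@H](COC(C)=O)[C@@H](O)[C@H]3O)c(=O)oc12` gives 216 ug/mL

Compound 2 at 216 ug/mL stands highest of the two measured compounds, and the gap down to compound 1 at 78.3 ug/mL lies beyond the scatter. The next compound is compound 3 `COc1cccc2cc(CSc3nc4cncnc4n3[C@@H]3O[C@H](CO)[C@@H](O)[C@H]3O)c(=O)oc12`, which differs from compound 2 by hydrogen in place of acetyl on an oxygen on a saturated carbon and carries hydrogen in place of acetyl on an oxygen on a saturated carbon, so that acetoxymethyl becomes hydroxymethyl. For the measured compounds named here, no measured pair shows this change on its own, which leaves the size of the step in this assay poorly defined. The only lead is the higher number of compound 2 at 216 ug/mL over compound 1 at 78.3 ug/mL and an upward step near the edge of the scatter is expected on that thin basis. The estimated change is a 1.9-fold higher number from compound 2 to compound 3 (0.29 log units; within the scatter) in this working view. For compound 3 the expected value is 420 ug/mL with an estimated range from 170 ug/mL to 900 ug/mL in this assay pending measurement.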

Compound 3, solubility: 224 ug/mL
The estimate for compound 3 lay 1.9-fold (0.27 log units) above the measured number, within the range that was stated.
By their numbers in this assay, from the lowest: compound 1; then compounds 2 and 3 (each within the scatter of the next).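

In this assay, hydrogen in place of acetyl on an oxygen on a saturated carbon, which turns acetoxymethyl into hydroxymethyl, now has a direct reading as a 1.0-fold higher number from compound 2 to compound 3 (0.02 log units; within the scatter). For the compounds shown here, at this position, the change therefore produces no step that can be told apart from the scatter, a point that compounds 1 and 2 could not settle, as they differ in more than one place. The series offers no measured information that would account for this result.

Still open, on these data alone, is whether a different group at this position, such as an amine, a carboxylic acid or a longer chain in place of the hydroxymethyl, would give a step beyond the scatter in this assay. Also open is what the acetyl groups on the other oxygens contribute when each is changed on its own, as no pair shown here isolates either of those changes.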